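This account rests on a few compounds, and the source may have more. Where it says the series, first, only, none or still open, it means among the compounds named here.

Of the compounds shown here, two that share one core have been measured in a functional assay on CHO cells for positive allosteric modulation of metabotropic glutamate receptor 2 (Homo sapiens), with a stated time of 30 min; a higher number here means a larger maximal response, a lower number a smaller maximal response. Compound 1, with the structure `CC(C)CCn1ccc(N2CCc3ccccc3C2)c(C#N)c1=O`, gives a maximal response of 310% in this assay. Compound 2, with the structure `CCCCn1ccc(N2CCC(c3ccccc3)CC2)c(C#N)c1=O`, gives 309% in this assay. Compound 2 therefore stands alongside compound 1: the two values are separated by an amount that lies within the usual scatter of repeated measurements, so no difference between them can be claimed.

The next compound, compound 3, with the structure `N#Cc1c(N2CCC(c3ccccc3)CC2)ccn(CCC2CC2)c1=O`, has not yet been measured. It differs from compound 2 in one place: cyclopropyl in place of ethyl on a saturated chain carbon, two bonds along the chain from an aromatic nitrogen. Going by the values given here, no measured pair in this set shows the effect of such a change, so the expectation rests only on compound 2 and the small size of the alteration. The step from compound 2 to compound 3 is expected to be a number 4 percentage points lower from compound 2 to compound 3 (within the scatter), which is a change that would not stand out from the scatter in either direction. Compound 3 is thus estimated to give about 305% in this assay, with a likely range from 250% to 360%.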

Compound 3, largest response reached (Emax), in percent of the reference or control that the assay uses: 316%
Estimate against measurement, compound 3: 11 percentage points below, and the stated range covers the measured number.
By their numbers in this assay, from the lowest: compounds 2, 1 and 3 (each within the scatter of the next).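

Replacing ethyl with cyclopropyl on a saturated chain carbon, two bonds along the chain from an aromatic nitrogen, turns the butyl chain of compound 2 into the 2-cyclopropylethyl chain of compound 3, and in this assay this gives a number 7 percentage points higher from compound 2 to compound 3 (within the scatter). Going by these compounds alone, this is the first pair here that differs in only one place, and it shows that this end of the chain can carry a three-membered carbon ring with no measurable difference in maximal response, at least on this core and with this one ring. Nothing at hand explains why the response holds across this change.

As far as these compounds go, a single pair cannot show how far this freedom extends, so it remains open whether a larger carbon ring such as cyclohexyl, an aromatic phenyl ring or a longer chain would also leave the maximal response unchanged. From the compounds shown here alone, it is equally open whether a group carrying other atoms, such as an amine or a hydroxyl, would shift the response beyond the scatter at this place.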